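The source may report more compounds than this note shows. Statements on the series, on what has been measured and on what is new or still open speak of the compounds shown alone.

Compound 1 `NCCCCCCOc1ccc2c(=O)c(-c3ccc(O)cc3)coc2c1` carries an amino group at the far end of its chain, and in an assay (Cricetulus griseus) for inhibition of aldehyde dehydrogenase, mitochondrial (Homo sapiens) (on this read-out lower numbers stand for stronger inhibition and higher numbers for weaker inhibition), compound 1 gives 100 nM. Among the three measured compounds this is the second highest number. Its nearest neighbour is compound 2 `O=c1c(-c2ccc(O)cc2)coc2cc(OCCCCCCO)ccc12`, which in this assay gives 120 nM, with a 1.2-fold higher number from compound 1 to compound 2 (0.08 log units; within the scatter). Furthest away is compound 3 `O=C(O)CCCCCCCCCOc1ccc2c(=O)c(-c3ccc(O)cc3)coc2c1`, which in this assay gives 50 nM, with a 2.0-fold lower number from compound 1 to compound 3 (0.30 log units; within the scatter). Between these two, a 2.4-fold lower number from compound 2 to compound 3 (0.38 log units; beyond the scatter).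

Compound 4 `CCCCCCCCCCCCOc1ccc2c(=O)c(-c3ccc(O)cc3)coc2c1` has not been measured. The change from compound 1 is hexyl in place of amino on a saturated chain carbon, six bonds along the chain from an oxygen on an aromatic ring. Among the measured compounds shown here, none of the measured steps tries this kind of swap: each of them exchanges one group that carries a hydrogen-bond donor for another that does, and all three such groups land within a narrow band of numbers. For the measured compounds named here, there is therefore no direct guide for hexyl at this place, and the only reasonable reading is that the end of the chain has so far mattered little, so compound 4 is expected to show no change at the digits printed from compound 1 to compound 4 (within the scatter), though with a wider spread than usual. The estimate for compound 4 in this assay is 100 nM, expected to fall between 35 nM and 300 nM.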

Compound 4, half-maximal inhibitory concentration: > 9000 nM
Compound 4: only a limit was reported; the forecaster's own chance of this, stated with the estimate: 5%; middle value at least 90-fold (1.95 log units) from the limit.
By their numbers in this assay, from the lowest: compounds 3, 1 and 2 (each within the scatter of the next, the first and the last beyond it). At a limit, above all of these: compound 4.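

Compound 4 is reported only as a limit: the limit of > 9000 nM in this assay, at which 1 of the 4 values shown sits. Replacing the chain-end group with plain carbon chain produces a large loss of inhibition against each of the other compounds, with an at least 90-fold higher number from compound 1 to compound 4 (1.95 log units; beyond the scatter), an at least 75-fold higher number from compound 2 to compound 4 (1.87 log units; beyond the scatter) and an at least 180-fold higher number from compound 3 to compound 4 (2.25 log units; beyond the scatter). The amino, hydroxy and carboxy ends had looked nearly interchangeable, but this result shows that the end of the chain is far from free, and chain length alone does not separate the compounds, since the step from compound 3 swaps carboxy for propyl on a saturated chain carbon, nine bonds along the chain from an oxygen on an aromatic ring, and compound 3 is itself a long-chain compound.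

The compounds shown do not separate the loss of a hydrogen-bond donor and acceptor at the chain end from the added carbons, so a short plain chain such as butyl would help to pull these two apart. From the compounds shown here alone, it also remains open whether a methoxy, a nitrile or an amide at the end of the chain would keep the numbers of compounds 1, 2 and 3.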